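Trifluoromethyl for bromo: working notes toward compound 4

This account rests on a few compounds, and the source may have more. Where it says the series, first, only, none or still open, it means among the compounds named here.

Three compounds of the series carry values in a functional assay on PC-3 cells (Homo sapiens) for antiproliferative activity, read by MTT assay, with a stated time of 72 h, tested at 5 uM; on this read-out higher numbers stand for more inhibition at the one concentration tested (going by the name of the read-out) and lower numbers for less inhibition. Compound 1 `CCOC(=O)/C(C#N)=C(/NNC(=O)c1cc(OC)c(OC)c(OC)c1)N[C@@H](C)c1ccccc1` gives 3.2%. Compound 2 `CCOC(=O)/C(C#N)=C(/Nc1ccc(C(F)(F)F)cc1)N[C@H](C)c1ccccc1` gives 59.4%. Compound 3 `CCOC(=O)/C(C#N)=C(/Nc1ccc(Br)cc1)N[C@@H](C)c1ccccc1` gives 24.7%, the second highest of the three numbers; its nearest neighbour is compound 1, whose value lies lower by a margin beyond the scatter, and its furthest is compound 2, whose value lies higher, again beyond the scatter.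

Compound 4 `CCOC(=O)/C(C#N)=C(/Nc1ccc(C(F)(F)F)cc1)N[C@@H](C)c1ccccc1` has not yet been measured in this assay. Relative to compound 3 the change is trifluoromethyl in place of bromo on an aromatic carbon. Going by the values given here, no step between two measured compounds covers this exact change, so the size of the step must be judged from the spread of the three numbers. Compound 2 also carries a trifluoromethyl group on an aromatic ring and gives 59.4%, well above compound 3, which suggests the entering group is compatible with higher inhibition within this small set; compound 1, with a different substituent pattern, sits at the bottom of the set. An upward step from compound 3, beyond the scatter but not necessarily reaching compound 2, is expected: a number 17.3 percentage points higher from compound 3 to compound 4 (beyond the scatter). Compound 4 is therefore estimated at 42%, with a range from 22% to 62%.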

Compound 4, a percentage reported as inhibition, at one concentration (the size of the read-out at that concentration, not a potency): 49.1%
Estimate against measurement, compound 4: 7.1 percentage points below; the range from low to high includes it.
By their numbers in this assay, from the lowest: compound 1; then compound 3; then compound 4; then compound 2.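

In this assay, going by these compounds alone, replacing bromo with trifluoromethyl on the aromatic carbon para to a large group gives a number 24.4 percentage points higher from compound 3 to compound 4 (beyond the scatter), the first direct reading of this position with the rest of the structure held constant, and it shows that inhibition at the one concentration tested depends on which of these two groups sits there. With trifluoromethyl kept in place, the stereocentre at the saturated chain carbon also registers, with a number 10.3 percentage points lower from compound 2 to compound 4 (beyond the scatter), so the series responds to the configuration as drawn as well as to the aromatic substituent. This second step can be assigned to that stereocentre alone because no other structural difference separates the pair: the fact that compounds 2 and 4 differ only in the configuration as drawn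

The compounds shown leave open whether the gain from bromo to trifluoromethyl carries over to the series drawn R at the stereocentre, and whether the configuration step has a similar size with bromo in place. On these data alone, it also remains open how an amine, a carboxylic acid or a single chlorine atom at the same aromatic carbon would compare with the two groups read here.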